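One Added Methyl on the Amide Chain of Compound 1

The source may report more compounds than this note shows. Statements on the series, on what has been measured and on what is new or still open speak of the compounds shown alone.

In a physicochemical assay for lipophilicity, at pH 7.4 (a higher number here means a more lipophilic compound, a lower number a more polar compound), compound 1 `CNC(=O)c1cccn(Cc2ccccc2)c1=O` gives 3, the middle of three measured numbers. Compound 2 `CNC(=O)c1cc(C(=O)NC)c(=O)n(Cc2ccccc2)c1` stands lower at 2.4, and compound 3 `CNC(=O)c1cc(C(=O)NCC(C)C)cn(Cc2ccccc2)c1=O` stands higher at 4.3. Compound 4 `CCNC(=O)c1cccn(Cc2ccccc2)c1=O` differs from compound 1 by methyl in place of hydrogen on a saturated chain carbon bound to an amide-type nitrogen, or methylcarbamoyl to ethylcarbamoyl. The nearest measured precedent is the large step of a number 1.90 log units higher from compound 2 to compound 3 (beyond the scatter), where isopropyl enters at the same kind of carbon. Methyl is the smaller group, so a modest rise in this assay is expected. The expected change is a number 0.40 log units higher from compound 1 to compound 4 (beyond the scatter). Compound 4 is estimated at 3.4, with an expected range of 3.1 to 3.8.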

Compound 4, distribution coefficient: 3.7
Beside the measured number, compound 4's estimate is 0.30 log units below it; measured number inside the range.
By their numbers in this assay, from the lowest: compound 2; then compound 1; then compound 4; then compound 3.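

In this assay, the single methyl in place of hydrogen gives a number 0.70 log units higher from compound 1 to compound 4 (beyond the scatter), so even the smallest group shown on a saturated chain carbon bound to an amide-type nitrogen moves the number beyond the scatter. The earlier step at this kind of carbon, a number 1.90 log units higher from compound 2 to compound 3 (beyond the scatter), entered isopropyl on a different compound, and both steps run upward. Nothing measured here accounts for the rise. As far as these compounds go, whether a longer chain such as propyl would extend the rise remains open. So does the effect of an amine carried on the ethyl chain.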